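The source may hold more compounds than are shown below. What is called first, only, known or untested is meant among the compounds shown, and "the series" means these compounds.

Compounds measured so far:
- compound 1 `CC(C)(C)N(NC(=O)c1ccccc1)C(=O)c1ccccc1Br`: 170 nM
- compound 2 `CC(C)(C)N(NC(=O)c1ccccc1)C(=O)c1ccccc1I`: 105 nM
- compound 3 `CC(C)(C)N(NC(=O)c1ccccc1F)C(=O)c1ccccc1Cl`: 51.3 nM

In an assay on cells for agonist activity at ecdysone receptor (Bombyx mori), read by a luciferase reporter, with a stated time of 24 h (on this read-out higher numbers stand for an effect only at larger amounts of compound and lower numbers for an effect already at smaller amounts), compound 3 gives the lowest of the three numbers: compared with compound 2 it gives a number lower by a margin beyond the scatter, and compared with compound 1 the margin is wider still. Compound 4 `CC(C)(C)N(NC(=O)c1ccccc1I)C(=O)c1ccccc1Cl` is not yet measured. It differs from compound 3 in one place: iodo in place of fluoro on an aromatic carbon.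

Within the data shown here, no measured step covers exactly this exchange. The only single-change step shown, a 1.6-fold lower number from compound 1 to compound 2 (0.21 log units; within the scatter), swaps one halogen for another at a different place in the molecule and stays within the scatter. Fluoro to iodo is a larger jump in the size of the halogen than bromo to iodo, so the closest available evidence is only a loose guide. On that basis a change in this assay of no more than modest size is expected, with the direction uncertain, so the expected step is a 1.3-fold higher number from compound 3 to compound 4 (0.10 log units; within the scatter). For compound 4 the estimate in this assay is 65 nM, with a likely range from 20 nM to 200 nM.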

Compound 4, half-maximal effective concentration: 1290 nM
Compound 4: the middle estimate sits 20-fold (1.30 log units) below what was measured; the whole stated range lies below it.
By their numbers in this assay, from the lowest: compound 3; then compounds 2 and 1 (each within the scatter of the next); then compound 4.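

In this assay, iodo in place of fluoro on this aromatic carbon, which turns 2-fluorophenyl into 2-iodophenyl, brings a large change: a 25-fold higher number from compound 3 to compound 4 (1.40 log units; beyond the scatter). Among these compounds, the only earlier exchange of halogens, at a different place in the molecule and from bromo rather than fluoro, gave a 1.6-fold lower number from compound 1 to compound 2 (0.21 log units; within the scatter), so the two steps together show that a swap of one halogen for another is not a small change everywhere, although they cannot separate the effect of the place from that of the particular halogens exchanged. No measurement shown accounts for the size of this step.

On these data alone, what a bromo or chloro group at this same place would give remains open, so it cannot be told whether the number climbs gradually along the halogens or jumps only with iodo. A methyl or methoxy group, or an amine, at this place would show whether the result is tied to halogens at all or holds for other groups as well.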